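The source may hold more compounds than are shown below. What is called first, only, known or untested is meant among the compounds shown, and "the series" means these compounds.

Working notes on the series. Compound 1 `CCn1c(C(=O)NCCCN(C)C)ccc1C(CC)(CC)c1ccc(OCCC(O)(CC)CC)c(C)c1` is the anchor: in a functional assay on Caco-2 cells (Homo sapiens) for antiproliferative activity, read by MTT assay, with a stated time of 48 h (on this read-out lower numbers stand for stronger inhibition and higher numbers for weaker inhibition), compound 1 gives 490 nM. Compound 2 `C=CCN(C)C(=O)c1ccc(C(CC)(CC)c2ccc(OCCC(O)(CC)CC)c(C)c2)n1CC` carries a changed amide; in this assay compound 2 gives only a limit, > 50000 nM, so its number is not pinned down. The step of an at least 100-fold higher number from compound 1 to compound 2 (2.00 log units; beyond the scatter) thus rests on that limit of > 50000 nM in this assay, at which 1 of the 2 values shown sits, and places compound 2 as the weaker of the two measured compounds. Compound 3 `CCn1c(C(=O)Nc2ccc(OC(F)(F)F)cc2)ccc1C(CC)(CC)c1ccc(OCCC(O)(CC)CC)c(C)c1` is the next change from compound 2: (4-(trifluoromethoxy)phenyl)amino in place of allyl(methyl)amino on a carbonyl carbon. Going by the values given here, no measured step covers an arylamide of this kind; the single step on record shows that removing the (3-(dimethylamino)propyl)amino group carries activity past the limit, and compound 3 does not restore that group. For compound 3 the step in this assay is expected to be a modest one toward a lower number and is estimated as an at least 4.1-fold lower number from compound 2 to compound 3 (0.61 log units; beyond the scatter). Compound 3 is expected to give 12000 nM, with a range from 2000 nM to 50000 nM.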

Compound 3, half-maximal inhibitory concentration: > 50000 nM
Compound 3 was reported as a limit; the forecaster's own chance of this, stated with the estimate: 40%; middle value at least 4.1-fold (0.61 log units) from the limit.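

Compound 3 also ends at a limit, not a number, in this assay: the limit of > 50000 nM in this assay, at which 2 of the 3 values shown sit. The change of 3-(dimethylamino)propyl to 4-(trifluoromethoxy)phenyl on the amide-type nitrogen is an at least 100-fold higher number from compound 1 to compound 3 (2.00 log units; beyond the scatter), so the hydrogen-bond donor that (4-(trifluoromethoxy)phenyl)amino brings and allyl(methyl)amino lacks is not enough on its own to give a measurable value on this carbonyl carbon. Two unlike replacements have now lost the number of compound 1, and the steps between the two limits cannot be read.

On these data alone, it remains open whether the dimethylamino group or the propyl chain is what counts at this position. A 3-hydroxypropyl amide and a 2-(dimethylamino)ethyl amide would separate the two, and neither is among the compounds shown.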